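The source may report more compounds than this note shows. Statements on the series, on what has been measured and on what is new or still open speak of the compounds shown alone.

Compound 1 `COc1cc2ncnc(N3CCc4ccccc43)c2cc1NC(=O)/C=C/CN1CCN(C)CC1` in a functional assay on A549 cells (Homo sapiens) for antiproliferative activity, read by MTT assay, with a stated time of 72 h (a lower number here means a stronger inhibitor, a higher number a weaker inhibitor), gives 5360 nM. Compound 2 `COc1cc2ncnc(N3CCc4ccccc43)c2cc1NC(=O)/C=C/CN1CCC(CO)CC1` carries the change (4-(hydroxymethyl)piperidin-1-yl in place of 4-methylpiperazin-1-yl on a saturated chain carbon bound to a double-bonded chain carbon); in this assay compound 2 gives 1980 nM, and the step of a 2.7-fold lower number from compound 1 to compound 2 (0.43 log units; beyond the scatter) lies beyond the scatter. Compound 3 `CN1CCN(C/C=C/C(=O)Nc2cc3c(N4CCCc5ccccc54)ncnc3cc2O[C@@H]2CCOC2)CC1` has a core unlike that of compound 1, and the difference between the two cores is not broken down here. In this assay compound 3 gives 5870 nM, a number within the scatter of that for compound 1 and beyond the scatter of that for compound 2. Compound 4 `O=C(/C=C/CN1CCC(CO)CC1)Nc1cc2c(N3CCCc4ccccc43)ncnc2cc1O[C@@H]1CCOC1` is not yet measured. Compound 4 differs from compound 3 by 4-(hydroxymethyl)piperidin-1-yl in place of 4-methylpiperazin-1-yl on a saturated chain carbon bound to a double-bonded chain carbon, the same change that separates compound 2 from compound 1, made at the same place. Among the compounds with values here, the expectation for compound 4 rests on the single earlier instance of this change, the step of a 2.7-fold lower number from compound 1 to compound 2 (0.43 log units; beyond the scatter); with one instance only, and on a core whose difference from that of compound 1 is not broken down, a step of similar size is expected but not assured. In this assay the estimated step is a 2.7-fold lower number from compound 3 to compound 4 (0.43 log units; beyond the scatter). For compound 4 in this assay the estimate is 2200 nM, with a range from 1100 nM to 4500 nM.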

Compound 4, half-maximal inhibitory concentration: 5300 nM
The estimate for compound 4 lay 2.4-fold (0.38 log units) below the measured number; measured number outside the range, above it.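

In this assay, 4-(hydroxymethyl)piperidin-1-yl in place of 4-methylpiperazin-1-yl gives a 1.1-fold lower number from compound 3 to compound 4 (0.04 log units; within the scatter), so on this core the two compounds cannot be separated. Even so, this step cannot be told apart from the earlier one: the same change on two cores in this assay, a 2.7-fold lower number (0.43 log units; beyond the scatter) from compound 1 to compound 2 and a 1.1-fold lower number (0.04 log units; within the scatter) from compound 3 to compound 4, 2.4-fold (0.39 log units) apart, within the scatter of two such steps With only two instances, the data do not show that the core alters the effect of the change, nor do they show that the step seen on the core of compound 1 carries over to the core of compound 3, so the transfer remains undecided.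

In both pairs, the second ring nitrogen leaves and the hydroxymethyl enters together, so it remains open which of the two accounts for the step from compound 1 to compound 2. A plain piperidin-1-yl or a morpholin-4-yl on the same saturated chain carbon, read on both cores, would separate those two parts of the change.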